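Urea terminus variation on the imidazolyl-phenoxy-phenyl core

This account rests on a few compounds, and the source may have more. Where it says the series, first, only, none or still open, it means among the compounds named here.

Among the measured compounds shown here, compound 2 `O=C(Nc1ccc(Oc2ccc(-c3ncc[nH]3)cc2)cc1)Nc1cc(C(F)(F)F)ccc1Cl` is the lower of the two numbers so far: in a functional assay on MDA-MB-231 cells (Homo sapiens) for inhibition, read by MTT assay and WST assay, with a stated time of 72 h, tested at 10 uM (on this read-out higher numbers stand for more inhibition of growth at the one concentration tested and lower numbers for less inhibition of growth), compound 2 gives 32.3%, whereas compound 1 `O=C(Nc1ccc(Cl)cc1)Nc1ccc(Oc2ccc(-c3ncc[nH]3)cc2)cc1` gives 47.6%. For the measured compounds named here, the only measured step, a number 15.3 percentage points lower from compound 1 to compound 2 (beyond the scatter), changed the same aryl group on the urea nitrogen and moved the read-out by a modest amount. Compound 3 `CC(=O)Oc1sccc1NC(=O)Nc1ccc(Oc2ccc(-c3ncc[nH]3)cc2)cc1` carries the change (2-acetoxythiophen-3-yl in place of 2-chloro-5-(trifluoromethyl)phenyl on an amide-type nitrogen). That site evidently matters, but one step in one direction gives no sign for a new group. Compound 3 is therefore expected near the middle of the two measured numbers, at 40% (range 22% to 58%), an expected step of a number 7.7 percentage points higher from compound 2 to compound 3 (within the scatter).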

Compound 3, percent growth inhibition at one concentration: -1.46%
The estimate for compound 3 lay 41.5 percentage points above the measured number; the whole stated range lies above it.
By their numbers in this assay, from the lowest: compound 3; then compound 2; then compound 1.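

On the amide-type nitrogen, this position can do more than trim the read-out: in this assay, 2-acetoxythiophen-3-yl gives a number 33.8 percentage points lower from compound 2 to compound 3 (beyond the scatter) and a number 49.1 percentage points lower from compound 1 to compound 3 (beyond the scatter). Compound 3 thus shows essentially no growth inhibition at the one concentration tested, while both chlorine-bearing phenyl termini retain a measurable effect. Nothing available explains this loss.

The thiophene ring and the acetoxy group enter together, so the loss cannot be assigned to either one. An unsubstituted thiophene or a phenyl ring carrying an acetoxy group would separate the two.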